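This account rests on a few compounds, and the source may have more. Where it says the series, first, only, none or still open, it means among the compounds named here.

Measured in a functional assay on MCF7 cells (Homo sapiens) for cytotoxicity, read by MTT assay, with a stated time of 72 h; on this read-out lower numbers stand for stronger inhibition and higher numbers for weaker inhibition:

compound 1 `O=c1ccc2nc(-c3ccccc3)nn(-c3ccccc3)c-2c1` gives 810 nM
compound 2 `CC(=O)Nc1cc2nc(-c3ccccc3)nn(-c3ccccc3)c-2cc1=O` gives > 5000 nM as a limit of the assay

Within the data shown here, compound 1 at 810 nM holds the only true number in this small set and is the sole anchor for what follows. Compound 2 sits at > 5000 nM and that value is a limit, not a number. Among the measured compounds shown here, the one measured step is an at least 6.1-fold higher number from compound 1 to compound 2 (0.79 log units; beyond the scatter) and it comes with acetamido in place of hydrogen on an aromatic carbon.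

Compound 3 `O=c1ccc2nc(C(F)(F)F)nn(-c3ccccc3)c-2c1` departs from compound 1 in another way: trifluoromethyl in place of phenyl on an aromatic carbon with trifluoromethyl in place of phenyl on an aromatic carbon, between two ring nitrogen atoms. For the measured compounds named here, the measured step involves neither of these groups, so it shows only that a change to the shared core can move the read-out in this assay and says little about direction here. No step beyond the scatter is therefore expected as the central case, though a wide margin on both sides is kept. The expected change is a 1.4-fold lower number from compound 1 to compound 3 (0.13 log units; within the scatter) on this estimate. Compound 3 is estimated to give 600 nM in this assay with an expected range from 120 nM to 3000 nM around it.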

Compound 3, half-maximal inhibitory concentration: 600 nM
Beside the measured number, compound 3's estimate shows no gap at the digits printed; the measured number falls inside the stated range.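

In this assay, the change at the aromatic carbon between two ring nitrogen atoms gives a 1.4-fold lower number from compound 1 to compound 3 (0.13 log units; within the scatter), so this read-out does not separate the two groups at this position. The phenyl that leaves holds a six-membered aromatic ring of carbon only and the trifluoromethyl that enters has no ring, so in this one pair an aromatic ring at this position is not required for a read-out on a par with that of compound 1. This is also the only step shown with a true number at both ends, since the other step ends at compound 2, whose value is a limit and not a number: the limit of > 5000 nM in this assay, at which 1 of the 3 values shown sits.

The compounds shown leave open how a methyl, an amine, a carboxylic acid or a longer chain at this position would read, so one pair marks no trend across groups here. They also leave open whether acetamido on the core of compound 3 would go the same way as it does on the core of compound 1.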